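The source may hold more compounds than are shown below. What is called first, only, known or untested is meant among the compounds shown, and "the series" means these compounds.

Measured so far:
compound 1 `O=C(Cc1csc2nc(-c3ccc(Br)cc3)cn12)N/N=C/c1ccccc1`: 51300 nM
compound 2 `COc1cccc(OC)c1/C=N/NC(=O)Cc1csc2nc(-c3ccc(Br)cc3)cn12`: 45700 nM

Both numbers come from a functional assay on Hs-578T cells (Homo sapiens) for inhibition, read by sulforhodamine B assay, with a stated time of 48 h; a lower number here means a stronger inhibitor of growth, a higher number a weaker inhibitor of growth. Among the compounds with values here, on these numbers, compound 2 cannot be told apart from compound 1: the only measured step, a 1.1-fold lower number from compound 1 to compound 2 (0.05 log units; within the scatter), lies within the scatter. Next comes compound 3 `O=C(Cc1csc2nc(-c3ccc(Br)cc3)cn12)N/N=C/c1ccc(Cl)cc1Cl`, with 2,4-dichlorophenyl in place of 2,6-dimethoxyphenyl on a carbon with a double bond to nitrogen. That one measured step bears on this change, as it also exchanged the group on that carbon. Within the data shown here, no measured compound carries the 2,4-dichlorophenyl group, so the evidence is thin. Still, with the earlier exchange making so little difference, no shift beyond the scatter is expected. The estimated change is a 1.0-fold lower number from compound 2 to compound 3 (0.01 log units; within the scatter). Compound 3 is expected at 45000 nM, with an estimated range from 20000 nM to 95000 nM.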

Compound 3, concentration for total growth inhibition: 89100 nM
Estimate against measurement, compound 3: 2.0-fold (0.30 log units) below; the range from low to high includes it.
By their numbers in this assay, from the lowest: compounds 2, 1 and 3 (each within the scatter of the next).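

In this assay, a second kind of substituted ring now sits on the carbon with a double bond to nitrogen: the 2,4-dichlorophenyl group gives a 1.9-fold higher number from compound 2 to compound 3 (0.29 log units; within the scatter) and, measured against the plain phenyl group, a 1.7-fold higher number from compound 1 to compound 3 (0.24 log units; within the scatter). Both steps stay within the scatter, so the chlorine-bearing, methoxy-bearing and unsubstituted phenyl groups cannot be told apart at this position, and the earlier flat result is not confined to the 2,6-dimethoxyphenyl group. Nothing measured here speaks to what lies behind these small steps.

From the compounds shown here alone, all three compounds keep a six-membered aromatic ring of carbon only at this place, so it remains open whether an amine or a carboxylic acid there would move the number beyond the scatter. Going by these compounds, the shared core is also identical throughout, so the effect of a change there remains unknown.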